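A few compounds are considered here, and "the series" means these few. Any claim that something is new, unique, unknown or untested is made for them only; others in the source may bear on it.

Measured compounds:
Compound 1, `CCCNC(=O)Nc1n[nH]c2c1CN(C(=O)C1CCN(C)CC1)C2(C)C`: 650 nM
Compound 3, `CC(C)(C)C(=O)N1Cc2c(NC(=O)C3CCNCC3)n[nH]c2C1(C)C`: 650 nM
Compound 2, `CC(=O)N1CCC(C(=O)N2Cc3c(NC(=O)c4ccc(F)cc4)n[nH]c3C2(C)C)CC1`: > 10000 nM, a limit of the assay and not a number

In a functional assay on A2780 cells (Homo sapiens) for antiproliferative activity, read by fluorescence, with a stated time of 72 h (a higher number here means a weaker inhibitor, a lower number a stronger inhibitor), compound 1 gives 650 nM. Compound 3 gives 650 nM, level with compound 1 at the digits shown, so the two lie within the usual scatter and no order can be read between them. Compound 2 yields no number in this assay but only (the limit of > 10000 nM in this assay, at which 1 of the 3 values shown sits).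

Compound 4, `CN1CCC(C(=O)N2Cc3c(NC(=O)c4ccc5ccccc5c4)n[nH]c3C2(C)C)CC1`, has not yet been measured in this assay. It differs from compound 1 in one place, on the carbonyl carbon whose other neighbour is the amide-type nitrogen: naphthalen-2-yl in place of propylamino on a carbonyl carbon

Among the compounds with values here, no step between two measured compounds that differ in exactly this way is available, so the size of the step must be guessed. Compound 2, which carries a different aromatic group on that carbonyl carbon but also differs from compound 1 elsewhere, sits at the limit, and this is the only hint at hand. The step is expected to weaken inhibition beyond the scatter, a 4.6-fold higher number from compound 1 to compound 4 (0.66 log units; beyond the scatter), with a real chance that only a limit is returned. Compound 4 is estimated at 3000 nM, with a range from 500 nM to 20000 nM.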

Compound 4, half-maximal inhibitory concentration: 270 nM
Compound 4: middle estimate off by 11-fold (1.05 log units), on the high side, and the stated range ends above it.
By their numbers in this assay, from the lowest: compound 4; then compounds 1 and 3 (each within the scatter of the next). At a limit, above all of these: compound 2.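

In this assay, setting naphthalen-2-yl in place of propylamino on the carbonyl carbon whose other neighbour is the amide-type nitrogen gives a 2.4-fold lower number from compound 1 to compound 4 (0.38 log units; beyond the scatter), a modest step and the only one shown at this place. The earlier compounds shown here offered no step here, and this one shows that the position accepts a much larger group of two six-membered aromatic rings of carbon only, and that activity in this assay survives the loss of the hydrogen-bond donor carried by propylamino. Nothing measured among these compounds explains why the step runs in this direction.

Going by these compounds, whether the second aromatic ring is needed remains open, since a plain phenyl on the same carbonyl carbon would separate the effect of one ring from that of two, and a pyridine would test the ring carbons themselves. On these data alone, it is also open whether a longer chain such as butylamino or a cyclic amine such as piperidine at this place would follow naphthalen-2-yl or stay level with propylamino.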